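Changing the ester side chain: chlorophenoxy gives way to benzyloxy

This account rests on a few compounds, and the source may have more. Where it says the series, first, only, none or still open, it means among the compounds named here.

Compound 1 `COC(=O)C1=C(C)NC(C)=C(C(=O)OCCc2ccc(Cl)cc2)C1c1cccc([N+](=O)[O-])c1`: 8 nM
Compound 2 `COC(=O)C1=C(C)NC(C)=C(C(=O)OCCOc2ccccc2Cl)C1c1cccc([N+](=O)[O-])c1`: 19 nM

Among the measured compounds shown here, in a functional assay on HEK293 cells for antagonist activity at Voltage-dependent L-type calcium channel subunit alpha-1C (Oryctolagus cuniculus), read by FLIPR (a higher number here means a weaker inhibitor, a lower number a stronger inhibitor), compound 2 gives the higher of the two numbers; the single step known, a 2.4-fold higher number from compound 1 to compound 2 (0.38 log units; beyond the scatter), lies beyond the scatter but is modest. Compound 3 `COC(=O)C1=C(C)NC(C)=C(C(=O)OCCOCc2ccccc2)C1c1cccc([N+](=O)[O-])c1` differs from compound 2 by benzyl in place of 2-chlorophenyl on an oxygen on a saturated carbon. For the measured compounds named here, no measured step bears directly on this exchange; the one available step altered a different part of the same side chain and was small. A step of similar size, or none beyond the scatter, is therefore expected in this assay. Compound 3 is estimated at 25 nM, with a range from 8 nM to 80 nM. The expected step of a 1.3-fold higher number from compound 2 to compound 3 (0.12 log units; within the scatter) is modest.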

Compound 3, half-maximal inhibitory concentration: 9 nM
Compound 3: the middle estimate sits 2.8-fold (0.44 log units) above what was measured; low and high end bracket the measured number.
By their numbers in this assay, from the lowest: compounds 1 and 3 (each within the scatter of the next); then compound 2.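

In this assay, the oxygen of this side chain carries benzyl with a modest gain over 2-chlorophenyl (a 2.1-fold lower number from compound 2 to compound 3 (0.32 log units; beyond the scatter)), so the position responds to this exchange, and the side chain needs no chlorine to reach the level of compound 1 (a 1.1-fold higher number from compound 1 to compound 3 (0.05 log units; within the scatter)). Benzyloxy and 4-chlorophenyl cannot be told apart here, as that step lies within the scatter. No evidence is available to account for either step. On these data alone, whether a chlorobenzyl group, a longer chain or an amine in this side chain would hold these numbers remains open.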